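Replacing a Sulfonyl Cap with a Urea on a Piperazine

This account rests on a few compounds, and the source may have more. Where it says the series, first, only, none or still open, it means among the compounds named here.

Compound 1 `C=CS(=O)(=O)N1CCN(c2ccn3ncc(-c4ccccc4)c3n2)CC1` gives 38300 nM in a functional assay on MDA-MB-231 cells (Homo sapiens) for antiproliferative activity, read by MTT assay, with a stated time of 48 h; on this read-out lower numbers stand for stronger inhibition and higher numbers for weaker inhibition.
Compound 2 `C=CS(=O)(=O)N1CCN(c2ncnc3sc(C4=CCCCC4)cc23)CC1` gives > 50000 nM, which is a limit of the assay and not a number; it sits at the limit of > 50000 nM in this assay, at which 1 of the 3 values shown sits.
Compound 3 `CN1CCN(c2ccc(-c3cc4c(N5CCN(S(=O)(=O)C6CC6)CC5)ncnc4s3)cc2)CC1` gives 11500 nM.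

Of the two numbers that are not limits, compound 3 has the lower one, and compound 1 stands higher by a gap that is beyond the usual scatter of this assay. So compound 3 is the reference point for the next change.

Compound 4 `COc1ccccc1NC(=O)N1CCN(c2ncnc3sc(-c4ccc(N5CCN(C)CC5)cc4)cc23)CC1` differs from compound 3 in a single place: (2-methoxyphenyl)carbamoyl in place of cyclopropylsulfonyl on an amine nitrogen in a ring. For the measured compounds named here, no pair of measured compounds shows this exact exchange, so nothing in the data gives the size of the step directly. The change adds a hydrogen-bond donor and an aromatic ring at the cap of the piperazine while the rest of the molecule stays the same.

Within these limits, a moderate improvement is expected for compound 4, a step of a 2.3-fold lower number from compound 3 to compound 4 (0.36 log units; beyond the scatter). The estimated value for compound 4 is 5000 nM, with a likely range from 1500 nM to 20000 nM.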

Compound 4, half-maximal inhibitory concentration: 23200 nM
The estimate for compound 4 lay 4.6-fold (0.67 log units) below the measured number, and the stated range ends below it.
By their numbers in this assay, from the lowest: compounds 3, 4 and 1 (each within the scatter of the next, the first and the last beyond it). At a limit, above all of these: compound 2.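

In this assay, putting (2-methoxyphenyl)carbamoyl in place of cyclopropylsulfonyl on an amine nitrogen in a ring gives a 2.0-fold higher number from compound 3 to compound 4 (0.30 log units; within the scatter). This first single-place comparison shows that the two caps cannot be told apart on this read-out, even though the entering group brings a six-membered aromatic ring and a hydrogen-bond donor that the leaving group lacks. Nothing measured here bears on what lies behind this result.

Still open, going by these compounds, is whether a urea cap with a carboxylic acid or a dimethylamino group on its aromatic ring, or a simple ethyl group in place of that ring, would give a number beyond the scatter from compound 3. Also open, on these data alone, is how a urea cap would behave on the core of compound 1, which carries a different cap.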